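Arylsulfonamide series: chloro for methyl, compound 4

The source may hold more compounds than are shown below. What is called first, only, known or untested is meant among the compounds shown, and "the series" means these compounds.

Of the three compounds measured in an ADME assay on L6 cells (Rattus norvegicus) for cytotoxicity (a lower number here means a stronger inhibitor, a higher number a weaker inhibitor), compound 2 `Cc1ccc(S(=O)(=O)N2c3ccccc3CCC2C)cc1` gives 4900 nM, the lowest number of the set; compound 1 `CC(=O)Nc1ccc(S(=O)(=O)N2c3ccccc3CCC2C)cc1` gives 52000 nM and compound 3 `CC1CCc2ccccc2N1S(=O)(=O)c1cccc([N+](=O)[O-])c1` gives 187000 nM. Among the measured compounds shown here, the only single-site step recorded among them is an 11-fold lower number from compound 1 to compound 2 (1.03 log units; beyond the scatter). Compound 4 `CC1CCc2ccccc2N1S(=O)(=O)c1ccc(Cl)cc1` follows from compound 2 by chloro in place of methyl on an aromatic carbon. For the measured compounds named here, no measured step exchanges one uncharged single-atom group for another, so the recorded step offers no direct guide, and compound 3 differs at more than one place. The step to compound 4 is therefore expected to be a 1.2-fold higher number from compound 2 to compound 4 (0.09 log units; within the scatter), not beyond the scatter. Compound 4 is estimated at 6000 nM, within a range from 2000 nM to 18000 nM.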

Compound 4, half-maximal inhibitory concentration: 20500 nM
Beside the measured number, compound 4's estimate is 3.4-fold (0.53 log units) below it; the measured number lies above the stated range.
By their numbers in this assay, from the lowest: compound 2; then compound 4; then compound 1; then compound 3.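

In this assay this aromatic carbon, para to a large group, responds even to an exchange of one single-atom group for another, with a 4.2-fold higher number from compound 2 to compound 4 (0.62 log units; beyond the scatter) for chloro in place of methyl. Chloro in place of acetamido gives a 2.5-fold lower number from compound 1 to compound 4 (0.40 log units; beyond the scatter) here, so among these three groups the order from the lowest number is methyl, chloro, acetamido. Nothing measured here explains this order. Where an amine, a methoxy group or a carboxylic acid would fall in this order at this carbon remains open.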